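Sulfonamide series: fluoro to methyl swap on compound 2

A few compounds are considered here, and "the series" means these few. Any claim that something is new, unique, unknown or untested is made for them only; others in the source may bear on it.

In a functional assay on B16-F10 cells (Mus musculus) for antiproliferative activity, read by MTT assay, with a stated time of 48 h (on this read-out higher numbers stand for weaker inhibition and lower numbers for stronger inhibition), compound 2 `O=C(Cc1ccc(F)cc1)NS(=O)(=O)c1ccc(F)cc1` gives 4.23 ug/mL, the highest of the two numbers in hand. Compound 1 `Cc1ncc([N+](=O)[O-])n1CC(=O)NS(=O)(=O)c1ccc(Cl)cc1` gives 0.92 ug/mL in this assay, a lower number by a gap beyond the scatter; the two structures differ in several places, so only the two values are set side by side. Compound 3 `Cc1ccc(S(=O)(=O)NC(=O)Cc2ccc(F)cc2)cc1` carries methyl in place of fluoro on an aromatic carbon, methyl in place of fluoro on an aromatic carbon. Within the data shown here, no measured step covers this change, so no movement beyond the scatter is expected. The estimate for compound 3 in this assay is 4.5 ug/mL, between 2 ug/mL and 10 ug/mL. This corresponds to an expected step of a 1.1-fold higher number from compound 2 to compound 3 (0.03 log units; within the scatter).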

Compound 3, half-maximal inhibitory concentration: 9.94 ug/mL
Compound 3: middle estimate off by 2.2-fold (0.34 log units), on the low side; the measured number falls inside the stated range.
By their numbers in this assay, from the lowest: compound 1; then compound 2; then compound 3.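

In this assay, among these compounds, the exchange of 4-fluorophenyl to 4-methylphenyl gives the first single-change reading, with a 2.3-fold higher number from compound 2 to compound 3 (0.37 log units; beyond the scatter) marking a modest loss of inhibition. This aromatic carbon, para to a large group, is therefore sensitive to its substituent, and methyl and fluoro are not interchangeable there. Nothing on hand accounts for the shift.

One pair cannot set a trend at this position. From the compounds shown here alone, how an amine, a methoxy group or a longer alkyl chain would read there remains open, as does whether the same exchange behaves alike on the core of compound 1.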